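The compounds below may be only part of what the source reports. "The series", "measured", "known", "first", "only" and "open" are said of these compounds alone.

Going by the values given here, in a functional assay for inhibition, with Homo sapiens as the target (on this read-out higher numbers stand for weaker inhibition and lower numbers for stronger inhibition), compound 2 `O=C(O)c1ccc2oc(NC(CC3CCCCC3)c3ccccc3)nc2c1` gives 150 nM, its only number, while one further entry carries none. Among the compounds with values here, compound 1 `c1ccc(C(CC2CCCCC2)Nc2nc3ccccc3o2)cc1` gives 340 nM; 8 nM; 6 nM (3 entries), a wide spread, and the single number for compound 2 sits inside it, higher than two of those three entries. Compound 3 `CN(C)C(=O)c1ccc2oc(NC(CC3CCCCC3)c3ccccc3)nc2c1` differs from compound 2 by dimethylamino in place of hydroxy on a carbonyl carbon. Within the data shown here, no measured pair shows this change, so any forecast is loose. A modest expected step, a 2.5-fold lower number from compound 2 to compound 3 (0.40 log units; beyond the scatter), points towards stronger inhibition. Compound 3 is estimated at 60 nM, with an expected range from 10 nM to 300 nM.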

Compound 3, half-maximal inhibitory concentration: 170 nM
The estimate for compound 3 lay 2.8-fold (0.45 log units) below the measured number, within the range that was stated.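

In this assay, putting dimethylamino in place of hydroxy on a carbonyl carbon gives a 1.1-fold higher number from compound 2 to compound 3 (0.05 log units; within the scatter). The carboxy and dimethylcarbamoyl groups therefore cannot be told apart here, and the hydrogen-bond donor of the hydroxy can go without a step beyond the scatter. Whether either group improves on compound 1, which lacks both, stays unclear because its entries spread widely: the several entries of compound 1 in this assay, 340 nM; 8 nM; 6 nM (3 entries)

On these data alone, whether a primary amide, a methyl ester or an amine would read the same in this place remains open.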